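Replacing 1H-pyrazol-1-yl with 2H-tetrazol-2-yl

This account rests on a few compounds, and the source may have more. Where it says the series, first, only, none or still open, it means among the compounds named here.

Values measured in a functional assay on HUVEC cells (Homo sapiens), read by scintillation counting and thymidine incorporation, with a stated time of 24 h (on this read-out higher numbers stand for weaker inhibition and lower numbers for stronger inhibition), for three compounds

- compound 1 `CCC(C)n1ncn(-c2ccc(N3CCN(c4ccc(OC[C@@H]5CO[C@@](CN(C)C)(c6ccc(Cl)cc6Cl)O5)cc4)CC3)cc2)c1=O` gives 1400 nM
- compound 2 `CCC(C)n1ncn(-c2ccc(N3CCN(c4ccc(OC[C@@H]5CO[C@@](CN6CCNCC6)(c6ccc(Cl)cc6Cl)O5)cc4)CC3)cc2)c1=O` gives 608 nM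
- compound 3 `CCC(C)n1ncn(-c2ccc(N3CCN(c4ccc(OC[C@@H]5CO[C@@](Cn6cccn6)(c6ccc(Cl)cc6Cl)O5)cc4)CC3)cc2)c1=O` gives 307 nM

Compound 3 sits level with compound 2 within the scatter and clearly lower than compound 1. Compound 4 `CCC(C)n1ncn(-c2ccc(N3CCN(c4ccc(OC[C@@H]5CO[C@@](Cn6ncnn6)(c6ccc(Cl)cc6Cl)O5)cc4)CC3)cc2)c1=O` carries 2H-tetrazol-2-yl in place of 1H-pyrazol-1-yl on a saturated chain carbon bound to a saturated ring carbon, a change counted as 2H-tetrazol-2-yl in place of 1H-pyrazol-1-yl on a saturated chain carbon bound to a saturated ring carbon in the two structures. Only changes at this same place bear on it, and they were small, namely a 2.3-fold lower number from compound 1 to compound 2 (0.36 log units; beyond the scatter) and a 4.6-fold lower number from compound 1 to compound 3 (0.66 log units; beyond the scatter) and a 2.0-fold lower number from compound 2 to compound 3 (0.30 log units; within the scatter) in that order. None of them swaps one five-membered aromatic ring for another, so no step beyond the scatter is expected. The expected step is a 1.1-fold lower number from compound 3 to compound 4 (0.04 log units; within the scatter) with no firm direction. The estimate for compound 4 is 280 nM with an expected range from 110 nM to 700 nM in this read-out.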

Compound 4, half-maximal inhibitory concentration: 124 nM
Compound 4: middle estimate off by 2.3-fold (0.35 log units), on the high side, and the stated range covers the measured number.
By their numbers in this assay, from the lowest: compound 4; then compounds 3 and 2 (each within the scatter of the next); then compound 1.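

In this assay the two five-membered aromatic rings are not interchangeable at this position: 2H-tetrazol-2-yl in place of 1H-pyrazol-1-yl brings a 2.5-fold lower number from compound 3 to compound 4 (0.39 log units; beyond the scatter) and so a step beyond the scatter. Among these compounds, compound 4 also stands clear of both amines, with a 4.9-fold lower number from compound 2 to compound 4 (0.69 log units; beyond the scatter) and an 11-fold lower number from compound 1 to compound 4 (1.05 log units; beyond the scatter) as the only large step at this place. Nothing measured here explains these steps.

As far as these compounds go, it remains open how a 1H-tetrazol-1-yl or 1H-1,2,3-triazol-1-yl ring would read on this carbon. Also open, from the compounds shown here alone, is whether a carboxylic acid or a longer chain there would keep the number this low.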